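The source may report more compounds than this note shows. Statements on the series, on what has been measured and on what is new or still open speak of the compounds shown alone.

Compound 2 `CCC(C)(CC)Cc1cnc(CCc2ccc(-c3ccccc3C(=O)O)cc2)[nH]1` gives 76 nM in an in vitro functional assay on cells for agonist activity at Bombesin receptor subtype-3 (Homo sapiens), read by luminescence and calcium flux (on this read-out higher numbers stand for an effect only at larger amounts of compound and lower numbers for an effect already at smaller amounts), the lowest of the two numbers recorded so far. For the measured compounds named here, its nearest neighbour is compound 1 `O=C(O)c1ccccc1-c1ccc(CCc2ncc(CC3CCOCC3)[nH]2)cc1`, which in this assay gives 338 nM; the one step known, a 4.4-fold lower number from compound 1 to compound 2 (0.65 log units; beyond the scatter), came from putting 1-ethyl-1-methylpropyl in place of oxan-4-yl on a saturated chain carbon bound to an aromatic carbon. Compound 3 `O=C(O)c1ccccc1-c1ccc(CCc2ncc(CC3CCCCCC3)[nH]2)cc1` has not yet been measured. It differs from compound 2 in one place: cycloheptyl in place of 1-ethyl-1-methylpropyl on a saturated chain carbon bound to an aromatic carbon. Going by the values given here, only the step from compound 1 to compound 2 bears on this change, and it concerned a different pair of groups, so it offers no direct guide. Since both 1-ethyl-1-methylpropyl and cycloheptyl are built of carbon only and are close in size, the change is expected to leave this assay little altered, amounting to a 1.3-fold higher number from compound 2 to compound 3 (0.12 log units; within the scatter). Compound 3 is therefore estimated at 100 nM, within a range from 40 nM to 300 nM.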

Compound 3, half-maximal effective concentration: 88 nM
Compound 3: middle estimate off by 1.1-fold (0.06 log units), on the high side, within the range that was stated.
By their numbers in this assay, from the lowest: compounds 2 and 3 (each within the scatter of the next); then compound 1.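

In this assay the cycloheptyl ring and the open-chain 1-ethyl-1-methylpropyl cannot be told apart on this saturated chain carbon (a 1.2-fold higher number from compound 2 to compound 3 (0.06 log units; within the scatter)), so closing the carbons into a ring brings no readable change here. Set against oxan-4-yl, cycloheptyl gives a second step in the same direction as the first (a 3.8-fold lower number from compound 1 to compound 3 (0.58 log units; beyond the scatter)), so among these three compounds both groups of carbon only stand apart from the oxygen-containing ring of compound 1. Nothing measured here accounts for that difference.

As far as these compounds go, whether the ring oxygen itself sets compound 1 apart remains open, and a piperidine ring carrying an amine nitrogen in its place would bear on that. The compounds also leave open how much smaller a carbon group can be at this place, as with cyclopentyl or a plain isopropyl.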